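The source may report more compounds than this note shows. Statements on the series, on what has been measured and on what is new or still open speak of the compounds shown alone.

Measured so far in a functional assay on A549 cells (Homo sapiens) for antiproliferative activity, read by MTT assay, with a stated time of 48 h; on this read-out lower numbers stand for stronger inhibition and higher numbers for weaker inhibition:
- compound 1 `N#Cc1nc2c(-c3nc4ccccc4[nH]3)c(N)n(CCO)c2nc1C#N`: > 50000 nM, a limit of the assay
- compound 2 `CN(C)CCCn1c(N)c(-c2nc3ccccc3[nH]2)c2nc(C#N)c(C#N)nc21`: 10400 nM
- compound 3 `CCN(CC)CCCn1c(N)c(-c2nc3ccccc3[nH]2)c2nc(C#N)c(C#N)nc21`: 25300 nM

Compound 3, at 25300 nM, has the higher of the two actual numbers, with compound 2 at 10400 nM. Compound 1 stands only as a limit, so it offers no number for comparison.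

The next case is compound 4 `N#Cc1nc2c(-c3nc4ccccc4[nH]3)c(N)n(CCCN3CCCCC3)c2nc1C#N`. The change is piperidin-1-yl in place of diethylamino on a saturated chain carbon, three bonds along the chain from an aromatic nitrogen: piperidin-1-yl in place of diethylamino, so a six-membered non-aromatic ring enters where compound 3 has no ring.

The closest measured precedent is an exchange at the same place on the chain: a 2.4-fold higher number from compound 2 to compound 3 (0.39 log units; beyond the scatter). Among the compounds with values here, that single modest step is the only one between two amino groups. The other two steps replace hydroxy and rest on a limit: an at least 4.8-fold lower number from compound 1 to compound 2 (0.68 log units; beyond the scatter) and an at least 1.9-fold lower number from compound 1 to compound 3 (0.29 log units; that floor lies within the scatter). They show little about exchanging one amino group for another.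

With so little precedent, compound 4 is expected to fall near the span set by compound 2 and compound 3. The estimated step is a 1.6-fold lower number from compound 3 to compound 4 (0.20 log units; within the scatter), so none beyond the scatter is expected. The estimate for compound 4 is 16000 nM, with an expected range from 7000 nM to 38000 nM.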

Compound 4, half-maximal inhibitory concentration: 6110 nM
The estimate for compound 4 lay 2.6-fold (0.42 log units) above the measured number, outside the stated range (below it).
By their numbers in this assay, from the lowest: compounds 4 and 2 (each within the scatter of the next); then compound 3. At a limit, above all of these: compound 1.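

In this assay, the exchange of amino groups at this place no longer runs one way with size: the earlier step to diethylamino raised the number, whereas piperidin-1-yl, with more heavy atoms and a six-membered non-aromatic ring, gives a 4.1-fold lower number from compound 3 to compound 4 (0.62 log units; beyond the scatter). Set against dimethylamino, the same group gives a 1.7-fold lower number from compound 2 to compound 4 (0.23 log units; within the scatter), so compound 2 and compound 4 cannot be ordered, and compound 3 is the one of the three amines whose number stands clear of both others. The step from hydroxy, an at least 8.1-fold lower number from compound 1 to compound 4 (0.91 log units; beyond the scatter), is only a floor and widens the known minimum gap between the hydroxy compound and the amines, with compound 1 held at a limit: the limit of > 50000 nM in this assay, at which 1 of the 4 values shown sits.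

On these data alone, what remains open is whether the ring as such accounts for the difference from diethylamino, which pyrrolidin-1-yl, morpholin-4-yl or 4-methylpiperazin-1-yl on the same 3-carbon propyl chain would help to separate. Also open, as far as these compounds go, is whether the piperidin-1-yl result holds on a different tether, such as 2-(piperidin-1-yl)ethyl or a longer chain than propyl.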